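Fluoro on the second phenyl: notes toward compound 4

The source may report more compounds than this note shows. Statements on the series, on what has been measured and on what is new or still open speak of the compounds shown alone.

Measured in a functional assay on HeLa cells (Homo sapiens) for antiproliferative activity, read by MTT assay, with a stated time of 48 h, in the presence of a further agent that is not named here; on this read-out higher numbers stand for weaker inhibition of growth and lower numbers for stronger inhibition of growth:
compound 1 `O=C(NOCc1ccccc1)c1cn(-c2ccccc2)nc1-c1ccccc1`, 8830 nM
compound 2 `O=C(NOCc1ccccc1F)c1cn(-c2ccccc2)nc1-c1ccccc1`, 11800 nM
compound 3 `O=C(NOCc1ccccc1Cl)c1cn(-c2ccccc2)nc1-c1ccccc1`, 17800 nM

All three numbers lie close together. Compound 2 is separated from compound 1 by a 1.3-fold higher number from compound 1 to compound 2 (0.13 log units; within the scatter) and from compound 3 by a 1.5-fold higher number from compound 2 to compound 3 (0.18 log units; within the scatter); compound 1 and compound 3 differ by a 2.0-fold higher number from compound 1 to compound 3 (0.30 log units; within the scatter). Among the compounds with values here, none of these steps leaves the scatter, so no compound can be called weaker or stronger than another on this evidence.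

Compound 4 `O=C(NOCc1ccccc1F)c1cn(-c2ccccc2)nc1-c1ccc(F)cc1` is compound 2 with one change: fluoro in place of hydrogen on an aromatic carbon. Within the data shown here, no measured pair touches this ring; the only halogen steps known, from compound 1 to compound 2 and from compound 1 to compound 3, sit on the other phenyl and were both within the scatter. With nothing pointing either way, the expectation for compound 4 in this assay is a step of about a 1.0-fold higher number from compound 2 to compound 4 (0.01 log units; within the scatter), that is, none beyond the scatter. The estimate for compound 4 is therefore 12000 nM, with a range from 5000 nM to 30000 nM.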

Compound 4, concentration for 50% growth inhibition: 10300 nM
Compound 4: the middle estimate sits 1.2-fold (0.07 log units) above what was measured, within the range that was stated.
By their numbers in this assay, from the lowest: compounds 1, 4, 2 and 3 (each within the scatter of the next).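

In this assay, within the data shown here, phenyl to 4-fluorophenyl, with the fluoro para to a large group, gives a 1.1-fold lower number from compound 2 to compound 4 (0.06 log units; within the scatter), the first reading at a ring that the earlier steps left unchanged. Fluoro at this place therefore stays within the scatter, as did the halogen steps on the other phenyl, but this single pair says nothing about other groups here. No supporting data are available to explain this step.

Still open, on these data alone, is whether an amine, a carboxylic acid or a longer chain at this place would give a step beyond the scatter. Also open, as far as these compounds go, is whether 4-fluorophenyl would read the same on the core of compound 1, which carries no halogen on the other phenyl.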